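A few compounds are considered here, and "the series" means these few. Any claim that something is new, unique, unknown or untested is made for them only; others in the source may bear on it.

Working notes on the series. Compound 3 `CC/N=C(\S)NCCCn1nc(-c2ccccc2)ccc1=O` stands at a limit in a functional assay on the whole organism (stomach) with Rattus norvegicus as the target; on this read-out lower numbers stand for an effect already at smaller amounts and higher numbers for an effect only at larger amounts of compound: compound 3 gives > 100 mg/kg, which is a limit and not a number. The two further values are limits as well. Compound 1 `O=c1ccc(-c2ccccc2)nn1CCCCNC(=S)Nc1ccccc1` gives in this assay > 100 mg/kg, a limit. Compound 2 `CCC/N=C(/NC#N)NCCCCn1nc(-c2ccccc2)ccc1=O` gives in this assay > 100 mg/kg, again a limit. Within the data shown here, the one step between measured compounds, a step that the two limits leave unreadable from compound 1 to compound 2, is left unreadable by the two limits. All that the measurements show so far is the limit of > 100 mg/kg in this assay, at which 3 of the 3 values shown sit.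

Compound 4 `CC/N=C(\S)NCCCCn1nc(-c2ccccc2)ccc1=O` differs from compound 3 by a group of 7 heavy atoms (4 carbon, 2 nitrogen, 1 sulfur; no ring) in place of a group of 6 heavy atoms (3 carbon, 2 nitrogen, 1 sulfur; no ring), on a saturated chain carbon, three bonds along the chain from an aromatic nitrogen. Among the measured compounds shown here, no measured step bears on this lengthening of the chain, and nothing measured departs from the limit. The step that the limit leaves unreadable from compound 3 to compound 4 is therefore expected to be none beyond the scatter, with compound 4 most likely remaining at a limit. The estimate for compound 4 in this assay is 150 mg/kg, between 60 mg/kg and 400 mg/kg.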

Compound 4, dose for half-maximal effect: 37.2 mg/kg
Compound 4: middle estimate off by 4.0-fold (0.61 log units), on the high side; the whole stated range lies above it.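

In this assay, lengthening the chain on a saturated chain carbon, three bonds along the chain from an aromatic nitrogen, gives an at least 2.6-fold lower number from compound 3 to compound 4 (0.42 log units; beyond the scatter), the first sign that chain length at this position affects the read-out. With the longer chain in place, the group on the amine nitrogen gives an at least 2.6-fold lower number from compound 2 to compound 4 (0.42 log units; beyond the scatter) and an at least 2.6-fold lower number from compound 1 to compound 4 (0.42 log units; beyond the scatter), so the group at that position also matters; all three sizes are minimum sizes, as each starting value is a limit and not a number. Compound 4 is the only compound with a measured number, and the others remain at a limit: the limit of > 100 mg/kg in this assay, at which 3 of the 4 values shown sit.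

As far as these compounds go, the true size of each step remains open. Also open, from the compounds shown here alone, is whether a longer chain, or a methyl group in place of the group on the amine nitrogen, would lower the number further.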